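Trimming one methoxy from a doubly trimethoxylated acrylonitrile

A few compounds are considered here, and "the series" means these few. Any claim that something is new, unique, unknown or untested is made for them only; others in the source may bear on it.

The measured compounds:
compound 1, `COc1ccc(C(=CC#N)c2ccc(OC)c(OC)c2)cc1OC`, 140 nM
compound 2, `CC=C(c1ccc(OC)c(N)c1)c1ccc(OC)c(OCC)c1`, 110 nM
compound 3, `COc1cc(C(=CC#N)c2cc(OC)c(OC)c(OC)c2)cc(OC)c1OC`, > 10000 nM

All three were tested in a functional assay on HCT-116 cells (Homo sapiens) for cytotoxicity, read by scintillation counting and thymidine incorporation, with a stated time of 72 h; a higher number here means a weaker inhibitor, a lower number a stronger inhibitor. Compound 1 gives 140 nM and compound 2 gives 110 nM; these two values lie within the usual scatter of each other, so neither can be called the stronger. Compound 3 stands apart: its result of > 10000 nM is a limit of the assay, not a number, and the compound is simply weaker than the assay could resolve. Going by the values given here, it is the one value sitting at the limit of > 10000 nM in this assay, at which 1 of the 3 values shown sits, among the three.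

The unmeasured compound 4, `COc1ccc(C(=CC#N)c2cc(OC)c(OC)c(OC)c2)cc1OC`, is reached from compound 3 by a single change: hydrogen in place of methoxy on an aromatic carbon. One of the two rings keeps its three methoxy groups while the other is brought to the two-methoxy pattern seen in compound 1. Among the compounds with values here, no measured pair isolates this exact change, so the size of the step is uncertain. Compound 1, with two dimethoxy rings, gives 140 nM. Compound 3, in contrast, was weaker than the assay could resolve. The expectation is that compound 4 falls between them, and the step of an at least 5.0-fold lower number from compound 3 to compound 4 (0.69 log units; beyond the scatter) is expected to be a gain in potency larger than the scatter. Compound 4 is therefore estimated at 2000 nM, with a range from 300 nM to 10000 nM in this assay.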

Compound 4, half-maximal inhibitory concentration: 41 nM
Compound 4: middle estimate off by 49-fold (1.69 log units), on the high side; the whole stated range lies above it.
By their numbers in this assay, from the lowest: compound 4; then compounds 2 and 1 (each within the scatter of the next). At a limit, above all of these: compound 3.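

In this assay, taking one methoxy off a fully trimethoxylated compound, at a place ortho to a methoxy group and meta to a large group, gives an at least 240-fold lower number from compound 3 to compound 4 (2.38 log units; beyond the scatter), so this single hydrogen in place of methoxy turns a compound with no measurable potency here into a potent one. The value of compound 3 is a limit of the assay, not a number: the limit of > 10000 nM in this assay, at which 1 of the 4 values shown sits.

The change also reads in the other direction, where methoxy in place of hydrogen on an aromatic carbon gives a 3.4-fold lower number from compound 1 to compound 4 (0.53 log units; beyond the scatter), so among these three compounds a third methoxy on one ring lowers the number, while a third on the second ring as well raises it beyond the limit.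

The compounds shown do not say why the same kind of change has opposite outcomes on the two rings, or whether this position accepts anything besides hydrogen and methoxy, such as a hydroxyl group or a chlorine atom. They also leave open whether the gain would survive replacing the nitrile with a carboxylic acid.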